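Swapping the aryl on the amide nitrogen: compound 1 to 3

The compounds below may be only part of what the source reports. "The series", "measured", "known", "first", "only" and "open" are said of these compounds alone.

Going by the values given here, compound 1 `NC(=O)c1ccc(N(Cc2ccc(C3CCCCC3)cn2)C(=O)[C@H]2CCN2S(=O)(=O)c2c(F)c(F)c(F)c(F)c2F)cc1O` is one of two compounds measured in a functional assay on MCF7 cells (Homo sapiens) for antiproliferative activity, with a stated time of 72 h (a lower number here means that less compound is needed, a higher number that more compound is needed for the effect), where compound 1 gives 4600 nM. Its companion compound 2 `O=C([C@H]1CCN1S(=O)(=O)c1c(F)c(F)c(F)c(F)c1F)N(Cc1ccc(C2CCCCC2)cc1)c1ccc2c(=O)[nH]ccc2c1` gives 6200 nM, a number that lies within the scatter of compound 1, so the two cannot be told apart. Compound 3 `O=C([C@H]1CCN1S(=O)(=O)c1c(F)c(F)c(F)c(F)c1F)N(Cc1ccc(C2CCCCC2)cn1)c1cc2[nH]ncc2cc1F` is not yet measured; it differs from compound 1 by 5-fluoro-1H-indazol-6-yl in place of 4-carbamoyl-3-hydroxyphenyl on an amide-type nitrogen. No comparable change has been measured here, yet compound 2 carries a different aryl at that place and sits close to compound 1, so the expected step of a 1.2-fold lower number from compound 1 to compound 3 (0.06 log units; within the scatter) is none beyond the scatter. Compound 3 is expected to give 4000 nM, within 1300 nM to 12000 nM.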

Compound 3, half-maximal effective concentration: 4800 nM
The estimate for compound 3 lay 1.2-fold (0.08 log units) below the measured number; the range from low to high includes it.
By their numbers in this assay, from the lowest: compounds 1, 3 and 2 (each within the scatter of the next).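

Going by these compounds alone, on the amide-type nitrogen, putting 5-fluoro-1H-indazol-6-yl in place of 4-carbamoyl-3-hydroxyphenyl gives a 1.0-fold higher number from compound 1 to compound 3 (0.02 log units; within the scatter) in this assay, the first comparison here of compounds that differ in this one place only. The two groups share a heavy-atom count but differ in their rings and in their numbers of hydrogen-bond donors and acceptors, yet the values stay within the scatter. Nothing measured here offers an explanation for this result.

Going by these compounds, whether any group at this place can move the number beyond the scatter remains open. An aryl carrying a carboxylic acid or an amine would test this.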